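The source may report more compounds than this note shows. Statements on the series, on what has been measured and on what is new or still open speak of the compounds shown alone.

Compound 1 `CCOc1ccc(C(=O)/C=C/c2c(/C=C/c3ccc(OC)cc3)cc(OC)cc2OC)cc1` gives 7.5 ug/mL in a functional assay on A549 cells (Homo sapiens) for antiproliferative activity, read by MTT assay, with a stated time of 48 h (a lower number here means a stronger inhibitor, a higher number a weaker inhibitor), which is the second highest of the three numbers in hand. Compound 2 `CCCCCCOc1ccc(C(=O)/C=C/c2c(/C=C/c3ccc(OC)cc3)cc(OC)cc2OC)cc1` gives 8.4 ug/mL in this assay, and compound 3 `COc1ccc(/C=C/c2cc(OC)cc(OC)c2/C=C/C(=O)c2ccc(C)c(C)c2)cc1` gives 0.1 ug/mL. The two known steps from compound 1 are a 1.1-fold higher number from compound 1 to compound 2 (0.05 log units; within the scatter) and a 75-fold lower number from compound 1 to compound 3 (1.88 log units; beyond the scatter). Compound 4 `COc1ccc(/C=C/c2cc(OC)cc(OC)c2/C=C/C(=O)c2ccc(OC)cc2)cc1` differs from compound 1 by hydrogen in place of methyl on a saturated chain carbon bound to an oxygen on an aromatic ring. Within the data shown here, of the measured steps, only the one to compound 2 bears on this change, since it also alters the chain on the oxygen on an aromatic ring, and it stayed within the scatter despite adding butyl; the large step to compound 3 concerns the group on the carbonyl carbon, a different place, and says nothing here. Shortening ethoxy to methoxy is therefore expected to give no step beyond the scatter, which is the expected step of no change at the digits printed from compound 1 to compound 4 (within the scatter). Compound 4 is thus estimated at 7.5 ug/mL, with an expected range from 3.5 ug/mL to 16 ug/mL.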

Compound 4, half-maximal inhibitory concentration: 4.5 ug/mL
For compound 4 the middle estimate is 1.7-fold (0.22 log units) above the measured one; measured number inside the range.
By their numbers in this assay, from the lowest: compound 3; then compounds 4, 1 and 2 (each within the scatter of the next).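

In this assay, the step from ethoxy to methoxy gives a 1.7-fold lower number from compound 1 to compound 4 (0.22 log units; within the scatter), and the longest chain set against methoxy gives a 1.9-fold lower number from compound 2 to compound 4 (0.27 log units; within the scatter), so the chain on this oxygen now stays within the scatter across compounds 1, 2 and 4, with methoxy as the shortest of them. The change on the carbonyl carbon gives a 45-fold higher number from compound 3 to compound 4 (1.65 log units; beyond the scatter), so the large gap seen with the ethoxy compound also appears with methoxy, and among these compounds it is the group on the carbonyl carbon that moves the number beyond the scatter. No available evidence accounts for either result.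

Going by these compounds, it remains open whether the low number of compound 3 needs both methyl groups, which a 4-methylphenyl or 3-methylphenyl group on the carbonyl carbon would test. On these data alone, the effect of a hydroxy group or an amine in place of the alkoxy chain is also open.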